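This account rests on a few compounds, and the source may have more. Where it says the series, first, only, none or still open, it means among the compounds named here.

In a functional assay on A2780 cells (Homo sapiens) for inhibition (a lower number here means a stronger inhibitor, a higher number a weaker inhibitor), three compounds on a shared core have numbers: compound 1 (`CCNC(=O)c1noc(-c2cc(C(C)C)c(O)cc2O)c1-c1cc(CO)no1`) gives 5 nM, compound 2 (`CCNCc1cc(-c2c(C(=O)NCC)noc2-c2cc(C(C)C)c(O)cc2O)on1`) gives 45 nM, and compound 3 (`CCNC(=O)c1noc(-c2cc(C(C)C)c(O)cc2O)c1-c1cc(C(=O)NC)no1`) gives 100 nM, the highest of the three. Compound 4 (`CCNC(=O)c1noc(-c2cc(C(C)C)c(O)cc2O)c1-c1ccn(C(C)C)n1`) differs from it as follows: 1-isopropyl-1H-pyrazol-3-yl in place of 3-(methylcarbamoyl)-1,2-oxazol-5-yl on an aromatic carbon. Within the data shown here, two measured steps bear on this change, the large 20-fold higher number from compound 1 to compound 3 (1.30 log units; beyond the scatter) and the modest 2.2-fold higher number from compound 2 to compound 3 (0.35 log units; beyond the scatter), but both alter only a substituent on the ring that compound 4 replaces whole. Among the measured compounds shown here, no measured compound carries the new group, so any expectation is loose. Compound 3 lies at the high end of the measured span, as a 2.2-fold higher number from compound 2 to compound 3 (0.35 log units; beyond the scatter) and a 20-fold higher number from compound 1 to compound 3 (1.30 log units; beyond the scatter) show, so a modest move to a lower number is expected rather than a rise. The expected change is a 2.0-fold lower number from compound 3 to compound 4 (0.30 log units; within the scatter), an estimate only. For compound 4 the estimated value is 50 nM, with an expected range from 12 nM to 200 nM.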

Compound 4, half-maximal inhibitory concentration: 45 nM
The estimate for compound 4 lay 1.1-fold (0.05 log units) above the measured number; the range from low to high includes it.
By their numbers in this assay, from the lowest: compound 1; then compounds 2 and 4 (each within the scatter of the next); then compound 3.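

In this assay exchanging the whole 3-(methylcarbamoyl)-1,2-oxazol-5-yl group for 1-isopropyl-1H-pyrazol-3-yl gives a 2.2-fold lower number from compound 3 to compound 4 (0.35 log units; beyond the scatter) and shows that this position accepts a different ring with 0 hydrogen-bond donors. Measured against the (ethylamino)methyl-bearing ring, the exchange shows no change at the digits printed from compound 2 to compound 4 (within the scatter) while against the hydroxymethyl-bearing ring it shows a 9.0-fold higher number from compound 1 to compound 4 (0.95 log units; beyond the scatter) and leaves that ring with the lowest number shown. Nothing available explains these differences. Going by these compounds, whether a hydroxymethyl or a carboxylic acid in place of the isopropyl on the new ring would approach compound 1 remains open.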